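The source may report more compounds than this note shows. Statements on the series, on what has been measured and on what is new or still open speak of the compounds shown alone.

Working notes on the series in a functional assay on MDA-MB-468 cells (Homo sapiens) for cytotoxicity, read by sulforhodamine B assay, with a stated time of 48 h, tested at 0.01 uM; a higher number here means a weaker effect of the compound at the concentration tested, a lower number a stronger effect. Going by the values given here, compound 2 `COc1cc(-c2cc(/C=C/C(=O)c3ccc(Cl)c(Cl)c3)[nH]n2)cc(OC)c1OC` gives 94%, the highest of the two numbers so far; its nearest neighbour is compound 1 `COc1cc(-c2cc(/C=C/C(=O)c3ccc(N)cc3)[nH]n2)cc(OC)c1OC`, which gives 90%, and the step of a number 4 percentage points higher from compound 1 to compound 2 (within the scatter) lies within the scatter. Compound 3 `COc1ccc(C(=O)/C=C/c2cc(-c3cc(OC)c(OC)c(OC)c3)n[nH]2)cc1OC` differs from compound 2 by 3,4-dimethoxyphenyl in place of 3,4-dichlorophenyl on a carbonyl carbon. Among the compounds with values here, the one measured step at this position, from 4-aminophenyl to 3,4-dichlorophenyl, changed little, so no step beyond the scatter is expected for a second aryl exchange at the carbonyl carbon. For compound 3 the estimate in this assay is 88%, with a range of 70% to 100%, the expected step being a number 6 percentage points lower from compound 2 to compound 3 (within the scatter).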

Compound 3, a percentage reported as activity, at one concentration (the size of the read-out at that concentration, not a potency): 89%
The estimate for compound 3 lay 1 percentage points below the measured number; measured number inside the range.
By their numbers in this assay, from the lowest: compounds 3, 1 and 2 (each within the scatter of the next).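

In this assay, three aryl groups on the carbonyl carbon now give readings within the scatter of one another. The exchange of chlorine for oxygen-bearing methoxy substituents, which adds hydrogen-bond acceptors, leaves no step beyond the scatter (a number 5 percentage points lower from compound 2 to compound 3 (within the scatter)), and neither does the comparison with the 4-aminophenyl compound (a number 1 percentage points lower from compound 1 to compound 3 (within the scatter)). No supporting data bear on the reason for this flat result.

Still open, on these data alone, is whether a non-aryl group here, such as a carboxylic acid or a longer alkyl chain, would give a step beyond the scatter. The shared core also stays unvaried in these compounds.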